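The source may hold more compounds than are shown below. What is called first, only, known or untested is meant among the compounds shown, and "the series" means these compounds.

Measured compounds in the series:
- compound 2 `C=C(Br)C(=O)Nc1cccc(-c2cn3nc(-c4ccc(OCC)cc4)sc3n2)c1` — in a functional assay on CCRF-CEM cells (Homo sapiens) for inhibition, read by cell counting, with a stated time of 3 days (on this read-out lower numbers stand for stronger inhibition and higher numbers for weaker inhibition), compound 2 gives 1400 nM.
- compound 3 `Nc1cccc(-c2cn3c(-c4ccccc4)csc3n2)c1` — in this assay compound 3 gives 29000 nM.
- compound 1 `CCOc1ccc(-c2nn3cc(-c4cccc(N)c4)nc3s2)cc1` — in this assay compound 1 reaches only a limit, > 250000 nM.

Compound 2 holds the lowest of the two numbers in this assay; compound 3 sits higher, beyond the scatter, and compound 1 contributes no number. Among the compounds with values here, the one single-point step measured is an at least 170-fold lower number from compound 1 to compound 2 (2.25 log units; beyond the scatter), which concerns the (1-bromoethenyl)carbonyl on the aromatic nitrogen. That step rests on a value that is a limit (the limit of > 250000 nM in this assay, at which 1 of the 3 values shown sits).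

Compound 4 `C=C(Br)C(=O)Nc1cccc(-c2cn3nc(CCc4ccccc4)sc3n2)c1` differs from compound 2 by phenethyl in place of 4-ethoxyphenyl on an aromatic carbon. Within the data shown here, no measured step touches this position: the step from compound 1 to compound 2 changes only the amide side, and both compound 2 and compound 4 keep the (1-bromoethenyl)carbonyl. The pair of compound 2 and compound 3 differs in more than one place and gives no clean reading either. With nothing measured on this change, a moderate step toward a higher number is expected for compound 4, a 2.9-fold higher number from compound 2 to compound 4 (0.46 log units; beyond the scatter). Compound 4 is therefore estimated at 4000 nM, with a range from 1000 nM to 20000 nM.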

Compound 4, half-maximal inhibitory concentration: 4200 nM
For compound 4 the middle estimate is 1.1-fold (0.02 log units) below the measured one, and the stated range covers the measured number.
By their numbers in this assay, from the lowest: compound 2; then compound 4; then compound 3. At a limit, above all of these: compound 1.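

Within the data shown here, at the aromatic carbon next to the ring sulfur, this is the first change measured with the (1-bromoethenyl)carbonyl held constant: in this assay, phenethyl in place of 4-ethoxyphenyl gives a 3.0-fold higher number from compound 2 to compound 4 (0.48 log units; beyond the scatter). The step is beyond the scatter but modest, so an aromatic ring attached directly at this carbon is not required for a measurable number in this pair. Nothing at hand gives a cause for this step.

The change removes the ethoxy group and inserts the phenethyl chain together, so the compounds shown do not separate the two contributions. Going by these compounds, how a benzyl group, a 4-ethoxyphenethyl group or a simple amine at this carbon would read remains open, as does whether the step holds on other amide groups.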